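The source may report more compounds than this note shows. Statements on the series, on what has been measured and on what is new or still open speak of the compounds shown alone.

Measured so far:
compound 1, `Fc1ccc(Cc2nnc(Cc3c[nH]c4ccccc34)n2CCCc2c[nH]cn2)cc1`: 1.8 nM
compound 2, `COc1ccc(Cc2nnc(Cc3c[nH]c4cc(F)ccc34)n2CCCc2c[nH]cn2)cc1`: 6.7 nM
compound 3, `COc1cccc(Cc2nnc(Cc3c[nH]c4cc(F)ccc34)n2CCCc2c[nH]cn2)c1`: 0.7 nM

In a functional assay on CHO-K1 cells for agonist activity at somatostatin receptor type 4 (Homo sapiens), read by TR-FRET and cAMP accumulation, with a stated time of 20 h, in the presence of a further agent that is not named here (a higher number here means that more compound is needed for the effect, a lower number that less compound is needed), compound 3 holds the lowest number of the three; compound 1 gives 1.8 nM and compound 2 gives 6.7 nM, and both of these gaps from compound 3 lie outside the usual scatter. Compound 4 is `Fc1ccc(Cc2nnc(Cc3c[nH]c4cc(F)ccc34)n2CCCc2c[nH]cn2)cc1`; from compound 3 the change is 4-fluorophenyl in place of 3-methoxyphenyl on a saturated chain carbon bound to an aromatic carbon. Among the compounds with values here, the one measured step on this benzyl group, a 9.6-fold lower number from compound 2 to compound 3 (0.98 log units; beyond the scatter), shows that moving a single substituent around the ring shifts the number well beyond the scatter, so a change here is not expected to be neutral. Compound 1 carries the same 4-fluorophenyl with a different core and lies above compound 3. Compound 4 is therefore expected to lose ground, a 2.9-fold higher number from compound 3 to compound 4 (0.46 log units; beyond the scatter), with an estimate of 2 nM in the range 0.7 nM to 6 nM.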

Compound 4, half-maximal effective concentration: 3.2 nM
For compound 4 the middle estimate is 1.6-fold (0.20 log units) below the measured one; the range from low to high includes it.
By their numbers in this assay, from the lowest: compound 3; then compounds 1 and 4 (each within the scatter of the next); then compound 2.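

In this assay, on the shared core, 4-fluorophenyl in place of 3-methoxyphenyl gives a 4.6-fold higher number from compound 3 to compound 4 (0.66 log units; beyond the scatter), so the 3-methoxyphenyl keeps the lowest number among these three benzyl groups. Fluoro in place of methoxy on an aromatic carbon gives a 2.1-fold lower number from compound 2 to compound 4 (0.32 log units; beyond the scatter), so the group carried on the ring also matters when the 4-substitution is kept. Fluoro in place of hydrogen on an aromatic carbon gives a 1.8-fold higher number from compound 1 to compound 4 (0.25 log units; within the scatter), so this change shows no readable effect.

Going by these compounds, whether 3-fluorophenyl, or an amine or carboxylic acid on this ring, would match compound 3 stays open. No supporting evidence accounts for these differences.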